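The source may hold more compounds than are shown below. What is called first, only, known or untested is meant among the compounds shown, and "the series" means these compounds.

Compound 1 has the structure `Fc1ccc([C@@H]2C[C@@H]3Cc4ccc5ccccc5c4N2O3)cc1`. In an ADME assay on Vero cells (Chlorocebus sabaeus) for cytotoxicity, read by MTT assay, with a stated time of 72 h (on this read-out higher numbers stand for lower toxicity in this test and lower numbers for higher toxicity in this test), compound 1 gives > 300000 nM, which is a limit of the assay rather than a number.
Compound 2 has the structure `COc1cccc([C@@H]2C[C@@H]3Cc4ccc5ccccc5c4N2O3)c1`. In this assay compound 2 gives > 300000 nM, again a limit and not a number.

Compound 2 therefore stands at the limit, as does everything shown here: the limit of > 300000 nM in this assay, at which 2 of the 2 values shown sit. Going by the values given here, the single step between measured compounds, a step that the two limits leave unreadable from compound 1 to compound 2, cannot be read because both ends are limits. Compound 3, `Cc1cccc([C@@H]2C[C@@H]3Cc4ccc5ccccc5c4N2O3)c1`, differs from compound 2 by methyl in place of methoxy on an aromatic carbon. No measured step bears on this change, and the one step shown is unreadable, so the expectation can only be that compound 3 stays where compound 2 stands, with a step that the limit leaves unreadable from compound 2 to compound 3 expected in this assay, none beyond the scatter. Compound 3 is estimated at 350000 nM in this assay, in the range 150000 nM to 900000 nM, most likely reported again as a limit.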

Compound 3, half-maximal cytotoxic concentration: > 300000 nM
Compound 3 ended at the assay's limit (the forecaster's own chance of this, stated with the estimate: 80%); the middle value is on the limit's open side.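

In this assay compound 3 gives > 300000 nM, again a limit and not a number. No step among compound 1, compound 2 and compound 3 can be read, and the values share one ceiling: the limit of > 300000 nM in this assay, at which 3 of the 3 values shown sit.

The compounds shown leave open whether any change to the aryl group would give a readable value in this assay.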